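Leaving the 5-bromo-2-hydroxyphenyl group of compound 3

The source may hold more compounds than are shown below. What is called first, only, known or untested is meant among the compounds shown, and "the series" means these compounds.

Among the compounds with values here, in a functional assay on BGC-823 cells (Homo sapiens) for cytotoxicity, read by MTT assay, with a stated time of 48 h (on this read-out higher numbers stand for weaker inhibition and lower numbers for stronger inhibition), compound 3 `O=C(CSc1nnc(-c2ccncc2)o1)N/N=C/c1cc(Br)ccc1O` gives 9590 nM, the lowest number of the three measured so far. Compound 1 `O=C(CSc1nnc(-c2ccncc2)o1)N/N=C/c1ccccc1` gives 22100 nM, and compound 2 `O=C(CSc1nnc(-c2ccncc2)o1)N/N=C/c1ccccc1[N+](=O)[O-]` gives 41600 nM. The next compound, compound 4 `O=C(CSc1nnc(-c2ccncc2)o1)N/N=C/c1ccc(Cl)cc1Cl`, has 2,4-dichlorophenyl in place of 5-bromo-2-hydroxyphenyl on a carbon with a double bond to nitrogen.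

Within the data shown here, two measured steps bear most directly on this change, as both introduce the group that compound 4 loses: a 2.3-fold lower number from compound 1 to compound 3 (0.36 log units; beyond the scatter) and a 4.3-fold lower number from compound 2 to compound 3 (0.64 log units; beyond the scatter). Both are modest and beyond the scatter. The remaining step, a 1.9-fold higher number from compound 1 to compound 2 (0.27 log units; within the scatter), lies within the scatter. Among the measured compounds shown here, no measured compound carries chlorine, so the size of the change remains uncertain.

Losing the group found in compound 3 is expected to give a modest step towards higher numbers in this assay, estimated as a 2.1-fold higher number from compound 3 to compound 4 (0.32 log units; beyond the scatter). For compound 4, the expected value is 20000 nM, with an estimated range of 8000 nM to 45000 nM.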

Compound 4, half-maximal inhibitory concentration: 35600 nM
Beside the measured number, compound 4's estimate is 1.8-fold (0.25 log units) below it, within the range that was stated.
By their numbers in this assay, from the lowest: compound 3; then compounds 1, 4 and 2 (each within the scatter of the next).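

In this assay the change to 2,4-dichlorophenyl gives a 3.7-fold higher number from compound 3 to compound 4 (0.57 log units; beyond the scatter) and so shows that a halogen-bearing phenyl at this place does not by itself keep the low number. The steps of a 1.2-fold lower number from compound 2 to compound 4 (0.07 log units; within the scatter) and a 1.6-fold higher number from compound 1 to compound 4 (0.21 log units; within the scatter) both lie within the scatter, so 2,4-dichlorophenyl cannot be told apart here from 2-nitrophenyl or plain phenyl. Compound 3 remains the only one of the four set apart, with steps beyond the scatter to each of the others. No available evidence accounts for this difference.

Neither the hydroxyl nor the bromine of 5-bromo-2-hydroxyphenyl appears alone in the compounds shown, so which of them goes with the lower number stays open. As far as these compounds go, how a phenyl carrying an amine or a carboxylic acid would read in this assay is also open.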